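Amide and sulfonamide variation on the piperidine nitrogen

The compounds below may be only part of what the source reports. "The series", "measured", "known", "first", "only" and "open" are said of these compounds alone.

The series shares a core that carries a six-membered non-aromatic ring with one nitrogen, the nitrogen bearing a changing acyl or sulfonyl group. Compound 1 `COc1ccc(-c2cn3cc(C4=CCN(C(=O)c5ccc(Cl)cc5)CC4)ccc3n2)cc1OC` carries a (4-chlorophenyl)carbonyl group there; in a functional assay on HeLa cells (Homo sapiens) for antiproliferative activity, read by MTT assay, with a stated time of 48 h (a lower number here means a stronger inhibitor, a higher number a weaker inhibitor), compound 1 gives 12200 nM. Compound 2 `COc1ccc(-c2cn3cc(C4=CCN(S(=O)(=O)C5CCCCC5)CC4)ccc3n2)cc1OC` carries a cyclohexylsulfonyl group instead, and in this assay compound 2 gives 9990 nM. The step of a 1.2-fold lower number from compound 1 to compound 2 (0.09 log units; within the scatter) does not separate the two. Among the two numbers, compound 2 has the lowest, with compound 1 nearest, within the scatter.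

Compound 3 `COc1ccc(-c2cn3cc(C4=CCN(C(=O)c5cccs5)CC4)ccc3n2)cc1OC` changes the same position: (thiophen-2-yl)carbonyl in place of cyclohexylsulfonyl on an amine nitrogen in a ring. Among the measured compounds shown here, only one measured step bears on this position, and it was a 1.2-fold lower number from compound 1 to compound 2 (0.09 log units; within the scatter), a swap between a sulfonyl and an aryl carbonyl that stayed within the scatter. The move to a (thiophen-2-yl)carbonyl group is again a sulfonyl-to-aryl-carbonyl swap at the same nitrogen, so no step beyond the scatter is expected in this assay, in either direction. Compound 3 is therefore expected to give about 11000 nM, within 5000 nM to 25000 nM, corresponding to an expected step of a 1.1-fold higher number from compound 2 to compound 3 (0.04 log units; within the scatter).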

Compound 3, half-maximal inhibitory concentration: 16000 nM
Beside the measured number, compound 3's estimate is 1.5-fold (0.16 log units) below it; measured number inside the range.
By their numbers in this assay, from the lowest: compounds 2, 1 and 3 (each within the scatter of the next).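

In this assay, the step of a 1.6-fold higher number from compound 2 to compound 3 (0.20 log units; within the scatter) shows that (thiophen-2-yl)carbonyl and cyclohexylsulfonyl on this ring nitrogen are not separated, even though the swap replaces a six-membered non-aromatic ring of carbon only with a five-membered aromatic ring with 1 hetero atom. The step of a 1.3-fold higher number from compound 1 to compound 3 (0.12 log units; within the scatter) adds a comparison that the first pair could not give: with the carbonyl kept, thiophen-2-yl in place of 4-chlorophenyl also stays within the scatter, so all three groups shown at this position now give numbers that cannot be told apart. No measurement is available that would explain this lack of separation.

As far as these compounds go, it remains open whether any group on this nitrogen can move the number beyond the scatter, for example an aminoacetyl group, an acyl group carrying a carboxylic acid, a longer alkyl chain on the sulfonyl, or a plain hydrogen on the ring nitrogen. Also open, from the compounds shown here alone, is whether a change on the shared core, such as a hydroxyl in place of a methoxy group, would shift the number in this assay more than any change at this nitrogen has so far.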